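A few compounds are considered here, and "the series" means these few. Any claim that something is new, unique, unknown or untested is made for them only; others in the source may bear on it.

Measured compounds:
Compound 2, `Oc1ccc(-c2cc(-c3cccc(Cl)c3)nc(-c3cccs3)c2)cc1`, with 5050 nM.
Compound 3, `Oc1ccc(-c2cc(-c3cccnc3)nc(-c3cccc(Cl)c3)c2)cc1`, with 21300 nM.
Compound 1, `Oc1cccc(-c2cc(-c3cccnc3)nc(-c3ccccc3Cl)c2)c1`, for which the result is "not determined" (no result reported).

The three compounds were tested in a functional assay on HCT-15 cells (Homo sapiens) for cytotoxicity, read by CCK-8 assay and cell counting, with a stated time of 2 days; a lower number here means a stronger inhibitor, a higher number a weaker inhibitor. Compound 3 gives 21300 nM and compound 2 gives 5050 nM. Between these two lies one change, (thiophen-2-yl in place of pyridin-3-yl on an aromatic carbon), and the step it made is a 4.2-fold lower number from compound 3 to compound 2 (0.63 log units; beyond the scatter). For compound 1 no number was reported in this assay, so nothing can be said about where it stands. Compound 1 and compound 3 are built from the same atoms joined differently; the difference between the two cores is not broken down here.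

The unmeasured compound 4, `Oc1cccc(-c2cc(-c3cccs3)nc(-c3ccccc3Cl)c2)c1`, differs from compound 1 by thiophen-2-yl in place of pyridin-3-yl on an aromatic carbon. Within the data shown here, this is the same kind of change as the one from compound 3 to compound 2, but not the same: in compound 3 and compound 2 the place is meta to a 3-chlorophenyl group and meta to a 4-hydroxyphenyl group, whereas in compound 1 and compound 4 it is meta to a 2-chlorophenyl group and meta to a 3-hydroxyphenyl group.

With no number for compound 1, the expectation for compound 4 cannot rest on a step from it and rests instead on compound 2, whose value 5050 nM is the only measured result with the same entering group. Compound 4 is therefore expected to give about 7000 nM in this assay, with an estimated range from 2000 nM to 30000 nM.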

Compound 4, half-maximal inhibitory concentration: 2790 nM
Estimate against measurement, compound 4: 2.5-fold (0.40 log units) above; low and high end bracket the measured number.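

Among these compounds, compound 4 gives 2790 nM in this assay while compound 1 stands at "not determined" (no result reported) and no step from compound 1 to compound 4 can be read. Nothing shown here offers a measured property that bears on this result. From the compounds shown here alone, what stays open is whether thiophen-2-yl in place of pyridin-3-yl changes the number on the core of compound 1 as it does in a 4.2-fold lower number from compound 3 to compound 2 (0.63 log units; beyond the scatter) on the other core.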